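Benzylidene arm of the shared core: adding methoxy

A few compounds are considered here, and "the series" means these few. Any claim that something is new, unique, unknown or untested is made for them only; others in the source may bear on it.

Compound 1, `COc1ccc(-c2cc(/N=C3/NC(=O)CS3)cs2)cc1`: in a functional assay on HT-29 cells (Homo sapiens) for cytotoxicity, read by MTT assay, with a stated time of 72 h (on this read-out higher numbers stand for weaker inhibition and lower numbers for stronger inhibition), a limit of the assay, > 50000 nM.
Compound 2, `O=C1N/C(=N/c2csc(-c3ccc(Cl)cc3)c2)S/C1=C\c1ccccc1`: 10500 nM in this assay.

Among the measured compounds shown here, compound 2 holds the only numerical value in this assay; the other result is a limit and not a number (the limit of > 50000 nM in this assay, at which 1 of the 2 values shown sits). For the measured compounds named here, compound 1 and compound 2 differ in more than one place, so no single step between measured compounds can be read, and their two values show only a limit against a number.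

Compound 3, `COc1ccc(/C=C2\S/C(=N\c3csc(-c4ccc(Cl)cc4)c3)NC2=O)cc1`, follows from compound 2 by one change: methoxy in place of hydrogen on an aromatic carbon. Nothing measured here speaks to a methoxy at that position of the shared core, so the step of a 1.3-fold lower number from compound 2 to compound 3 (0.12 log units; within the scatter) is expected to be small, at most a slight move toward stronger inhibition and possibly none beyond the scatter. Compound 3 is accordingly estimated at 8000 nM, with a range of 3000 nM to 25000 nM.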

Compound 3, half-maximal inhibitory concentration: 3800 nM
The estimate for compound 3 lay 2.1-fold (0.32 log units) above the measured number, and the stated range covers the measured number.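

In this assay, among the compounds shown here, the change from phenyl to 4-methoxyphenyl on the benzylidene arm gives the first step that can be read as a number: a 2.8-fold lower number from compound 2 to compound 3 (0.44 log units; beyond the scatter) is a modest move toward stronger inhibition. The earlier compounds shown here gave no reading at this position; it now accepts methoxy, para to a large group, without loss, and the change brings a small gain that lies beyond the usual scatter. Nothing given here bears on the reason for this step.

Still open, going by these compounds, is whether the gain is particular to methoxy or would also appear with a hydroxyl, an amine or a carboxylic acid at the same place. Also open, on these data alone, is whether the step would hold if the 4-chlorophenyl group of compound 2 and compound 3 were replaced by another group.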